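The source may hold more compounds than are shown below. What is called first, only, known or untested is meant among the compounds shown, and "the series" means these compounds.

Series on the shared core of compound 1 `CNC(=O)c1cc(-c2ccc(NS(=O)(=O)c3cccc(Cl)c3Cl)cc2)nc2[nH]ncc12`, followed in an assay for inhibition of serine/threonine-protein kinase Sgk1 (Homo sapiens), with stated times of 30 min and 60 min, in the presence of a further agent that is not named here; on this read-out lower numbers stand for stronger inhibition and higher numbers for weaker inhibition. Compound 1 gives 929 nM. Compound 2 `NCCNC(=O)c1cc(-c2ccc(NS(=O)(=O)c3cccc(Cl)c3Cl)cc2)nc2[nH]ncc12` reaches the limit of the assay, < 1 nM, so only a bound is known for it (the limit of < 1 nM in this assay, at which 1 of the 2 values shown sits). Within the data shown here, the single measured step, an at least 920-fold lower number from compound 1 to compound 2 (2.96 log units; beyond the scatter), is large. Compound 3 `CN1CCC(CNC(=O)c2cc(-c3ccc(NS(=O)(=O)c4cccc(Cl)c4Cl)cc3)nc3[nH]ncc23)C1` differs from compound 2 by 1-methylpyrrolidin-3-yl in place of aminomethyl on a saturated chain carbon bound to an amide-type nitrogen. Among the measured compounds shown here, no measured step covers this exchange, and compound 2 sits at the limit, so the direction is open. The expected step is an at least 3.0-fold higher number from compound 2 to compound 3 (0.47 log units; beyond the scatter), a small move that may not exceed the scatter. Compound 3 is estimated at 3 nM, between 0.5 nM and 30 nM.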

Compound 3, half-maximal inhibitory concentration: 45 nM
Estimate against measurement, compound 3: 15-fold (1.18 log units) below, and the stated range ends below it.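

In this assay, 1-methylpyrrolidin-3-yl on the saturated chain carbon bound to an amide-type nitrogen gives up much of what aminomethyl delivers, with an at least 45-fold higher number from compound 2 to compound 3 (1.65 log units; beyond the scatter). Compound 2 carries a limit, so this step is only a bound: the limit of < 1 nM in this assay, at which 1 of the 3 values shown sits. The gain does not depend on aminomethyl alone, since 1-methylpyrrolidin-3-yl still shows a 21-fold lower number from compound 1 to compound 3 (1.31 log units; beyond the scatter).

The compounds shown do not separate the contributions of the ring, the methyl on its nitrogen and the loss of the amine hydrogens. Pyrrolidin-3-yl without the methyl, or an open-chain dimethylamine, would bear on that.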